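Chloro for Fluoro on a Selenocyanate Carbamate

The source may hold more compounds than are shown below. What is called first, only, known or untested is meant among the compounds shown, and "the series" means these compounds.

Compound 1 `N#C[Se]c1ccc(NC(=O)Oc2ccc(F)cc2)cc1` was tested in a functional assay on MCF7 cells (Homo sapiens) for cytotoxicity, read by MTT assay, with a stated time of 72 h (on this read-out higher numbers stand for lower toxicity in this test and lower numbers for higher toxicity in this test), where compound 1 gives 65700 nM. Two diselenide carbamates accompany it: compound 2 `CCOC(=O)Nc1ccc([Se][Se]c2ccc(NC(=O)OCC)cc2)cc1` gives 68300 nM in this assay, and compound 3 `O=C(Nc1ccc([Se][Se]c2ccc(NC(=O)OCc3ccccc3)cc2)cc1)OCc1ccccc1` gives 74500 nM in this assay. Compound 1 has the lowest of the three numbers, yet its differences from compound 2 and from compound 3 both fall within the scatter of repeated measurements, so the three compounds cannot be told apart on these data.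

Compound 4 `N#C[Se]c1ccc(NC(=O)Oc2ccc(Cl)cc2)cc1` has not yet been measured. It differs from compound 1 only in this way: chloro in place of fluoro on an aromatic carbon. Going by the values given here, no step between two measured compounds informs what such a change does here; the three measured values sit close together and none of them involves this change. With a single halogen swapped for another on the same aromatic carbon, the step from compound 1 to compound 4 is expected to be a 1.1-fold lower number from compound 1 to compound 4 (0.04 log units; within the scatter), that is, no movement beyond the scatter. Compound 4 is therefore estimated at 60000 nM in this assay, within a range of 25000 nM to 150000 nM.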

Compound 4, concentration lethal to 50% of the cells in the MCF7 assay: 63600 nM
Compound 4: middle estimate off by 1.1-fold (0.03 log units), on the low side; measured number inside the range.
By their numbers in the MCF7 assay, from the lowest: compounds 4, 1, 2 and 3 (each within the scatter of the next).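

Chloro in place of fluoro on an aromatic carbon, para to a large group, is the first single change seen at this position, and in the MCF7 assay it gives a 1.0-fold lower number from compound 1 to compound 4 (0.01 log units; within the scatter) for this halogen swap on the selenocyanate carbamate. In a physicochemical assay, with a stated time of 6 min, tested at 0.1 mg/mL (a lower number here means less inhibition, a higher number more inhibition at the concentration tested (going by the name of the read-out)), compound 1 gives > 25% as its result, which is a limit of the assay and not a number. In the physicochemical assay compound 4 gives > 25% as its result, which is likewise a limit.

The step between these two compounds in the physicochemical assay therefore cannot be read, and both results stop at the same limit: the limit of > 25% in the physicochemical assay, at which 2 of the 2 values shown sit. As far as these compounds go, whether an amine, a carboxylic acid or a methoxy group at this position would move the number in the MCF7 assay beyond the scatter stays open.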